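A few compounds are considered here, and "the series" means these few. Any claim that something is new, unique, unknown or untested is made for them only; others in the source may bear on it.

Going by the values given here, compound 3, `COc1cc2c(Oc3ccc(NC(=O)c4nnn(-c5ccc(C)cc5)c4C(F)(F)F)cc3F)ccnc2cc1OCCCN1CCC(C)CC1`, stands at the higher of the two numbers so far obtained in a functional assay on U-87MG ATCC cells (Homo sapiens) for cytotoxicity, read by MTT assay, with a stated time of 72 h; on this read-out higher numbers stand for weaker inhibition and lower numbers for stronger inhibition. In this assay compound 3 gives 2800 nM. Compound 2, `COc1cc2c(Oc3ccc(NC(=O)c4nnn(-c5ccccc5)c4C)cc3F)ccnc2cc1OCCCN1CCC(C)CC1`, gives 1240 nM in this assay, and the gap between these two values lies beyond the usual scatter of repeated measurements. Compound 1, `COc1cc2c(Oc3ccc(NC(=O)c4nnn(-c5ccc(C)cc5)c4C(F)(F)F)cc3F)ccnc2cc1OCCCN1CCCC1`, has the entry "not determined" (no result reported) in this assay, so it offers no number for comparison.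

Compound 4, `COc1cc2c(Oc3ccc(NC(=O)c4nnn(-c5ccc(F)c(F)c5)c4C(F)(F)F)cc3F)ccnc2cc1OCCCN1CCC(C)CC1`, is derived from compound 3 by a single change: 3,4-difluorophenyl in place of 4-methylphenyl on an aromatic nitrogen. Among the compounds with values here, no pair of measured compounds differs only in this way, so the measured data give no direct guide to the size or direction of the step. On that basis the step from compound 3 to compound 4 is expected to be small, a 1.3-fold lower number from compound 3 to compound 4 (0.10 log units; within the scatter), and most likely within the scatter, with no firm reason to predict stronger or weaker inhibition. Compound 4 is therefore estimated at 2200 nM in this assay, with a plausible range from 700 nM to 7000 nM.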

Compound 4, half-maximal inhibitory concentration: 1150 nM
Compound 4: the middle estimate sits 1.9-fold (0.28 log units) above what was measured; measured number inside the range.
By their numbers in this assay, from the lowest: compounds 4 and 2 (each within the scatter of the next); then compound 3.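

In this assay, the aromatic nitrogen of the five-membered ring, next to the ring atom that bears the trifluoromethyl group, now has a measured step: 3,4-difluorophenyl in place of 4-methylphenyl gives a 2.4-fold lower number from compound 3 to compound 4 (0.39 log units; beyond the scatter). The change is modest, but it shows that the number responds to what the phenyl ring on this nitrogen carries, and here the swap goes toward stronger inhibition. No measurement shown explains the shift, so its cause remains unknown.

This is a single pair, so it cannot show whether both fluorines are needed or whether the loss of the methyl group matters more. A phenyl ring carrying one fluorine, or a pyridine ring on the same nitrogen, would help separate these possibilities.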